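This account rests on a few compounds, and the source may have more. Where it says the series, first, only, none or still open, it means among the compounds named here.

Two compounds of a shared core, which differ only in the group attached to a five-membered aromatic ring with three nitrogens, have been measured in an assay for inhibition of histone-lysine N-methyltransferase, H3 lysine-79 specific (Homo sapiens), read by scintillation counting, with stated times of 15 min and 60 min, tested at 50 uM, in the presence of a further agent that is not named here; a lower number here means a weaker effect, a higher number a stronger effect of the compound at the concentration tested. Compound 1 `Fc1ccc(-c2nnc3sc(/C=C/c4ccco4)nn23)cc1` gives 44% in this assay, and compound 2 `Cc1cccc(-c2nnc3sc(/C=C/c4ccco4)nn23)c1` gives 69%. Within the data shown here, on these two numbers compound 2 stands highest, and the one measured step, a number 25 percentage points higher from compound 1 to compound 2 (beyond the scatter), lies beyond the scatter.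

Compound 3 `C(=C/c1nn2c(C3CCCCC3)nnc2s1)\c1ccco1` is not yet measured. Its change from compound 2 is cyclohexyl in place of 3-methylphenyl on an aromatic carbon. The measured step bears only loosely on this change, since it swapped one six-membered aromatic ring of carbon for another, whereas here a non-aromatic ring enters. Without a closer comparison, compound 3 is expected to give about 45% in this assay, within a wide range from 15% to 75%, which means an expected step of a number 24 percentage points lower from compound 2 to compound 3 (beyond the scatter).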

Compound 3, a percentage reported as inhibition, at one concentration (the size of the read-out at that concentration, not a potency): 68%
Beside the measured number, compound 3's estimate is 23 percentage points below it, within the range that was stated.
By their numbers in this assay, from the lowest: compound 1; then compounds 3 and 2 (each within the scatter of the next).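

In this assay the change to cyclohexyl gives a number 1 percentage points lower from compound 2 to compound 3 (within the scatter) and so shows that the group on this aromatic carbon, between two ring nitrogen atoms, need not be an aromatic ring: a six-membered non-aromatic ring of carbon only serves as well as 3-methylphenyl. The change from 4-fluorophenyl gives a number 24 percentage points higher from compound 1 to compound 3 (beyond the scatter) and places compound 1 apart from both other compounds, since a number 25 percentage points higher from compound 1 to compound 2 (beyond the scatter) also lies beyond the scatter. No measurement shown here explains why these groups read as they do.

Going by these compounds, whether a ring is needed here at all remains open, and an open chain such as butyl, or a small group such as methyl, would address that. Also open, on these data alone, is how an amine or a carboxylic acid on this carbon would read, and whether plain phenyl would stand with compound 1 or with compound 2.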